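A few compounds are considered here, and "the series" means these few. Any claim that something is new, unique, unknown or untested is made for them only; others in the source may bear on it.

Three compounds share one core, differing only in the group carried on a saturated chain carbon bound to an aromatic carbon. Compound 1 `O=C(O)/C=C/c1ccc(Cn2cccn2)cc1OCCc1ccc2ccccc2c1` gives 73 nM in an in vitro functional assay on CHO cells for antagonist activity at prostaglandin E2 receptor EP3 subtype (Mus musculus); a lower number here means a stronger inhibitor, a higher number a weaker inhibitor. Compound 2 `O=C(O)/C=C/c1ccc(Cn2ccnc2)cc1OCCc1ccc2ccccc2c1` gives 50 nM in this assay; the step of a 1.5-fold lower number from compound 1 to compound 2 (0.16 log units; within the scatter). Compound 3 `O=C(O)/C=C/c1ccc(Cc2ccccc2)cc1OCCc1ccc2ccccc2c1` gives 400 nM in this assay, the highest of the three numbers: the step of a 5.5-fold higher number from compound 1 to compound 3 (0.74 log units; beyond the scatter), and the step of an 8.0-fold higher number from compound 2 to compound 3 (0.90 log units; beyond the scatter).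

Compound 4 `O=C(O)/C=C/c1ccc(COc2ccccc2)cc1OCCc1ccc2ccccc2c1` has not yet been measured. It differs from compound 3 in this way: phenoxy in place of phenyl on a saturated chain carbon bound to an aromatic carbon. Going by the values given here, no measured step swaps phenyl for phenoxy; the two measured steps ending at compound 3 only show that phenyl in place of a pyrazolyl or imidazolyl gave a modestly higher number. From the compounds shown here alone, the effect of the added oxygen is unknown from these data.

Compound 4 is therefore expected to land near compound 3, with the step of a 1.3-fold lower number from compound 3 to compound 4 (0.12 log units; within the scatter) expected to stay within the scatter, and its value in this assay is estimated at 300 nM, likely between 100 nM and 1000 nM.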

Compound 4, half-maximal inhibitory concentration: 140 nM
For compound 4 the middle estimate is 2.1-fold (0.33 log units) above the measured one; low and high end bracket the measured number.
By their numbers in this assay, from the lowest: compounds 2, 1 and 4 (each within the scatter of the next, the first and the last beyond it); then compound 3.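

In this assay, the phenyl group on this saturated chain carbon is not the only outcome for a carbon-only aromatic ring, since phenoxy in place of phenyl gives a 2.9-fold lower number from compound 3 to compound 4 (0.46 log units; beyond the scatter), so the oxygen-linked ring recovers part of what phenyl lost. Compared with the two nitrogen-containing rings, the result splits: there is a 2.8-fold higher number from compound 2 to compound 4 (0.45 log units; beyond the scatter), which keeps phenoxy apart from 1H-imidazol-1-yl, while a 1.9-fold higher number from compound 1 to compound 4 (0.28 log units; within the scatter) does not separate phenoxy from 1H-pyrazol-1-yl. Nothing available here speaks to the reason for any of these steps.

From the compounds shown here alone, it remains open whether the oxygen itself or simply the longer link matters, a question that a phenethyl group at this place would address. Also open, going by these compounds, is how a chlorine or a methoxy group on the phenoxy ring, or an amine such as piperidinyl in its place, would shift the number.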